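One Piperazine Swap on Compound 1

The source may report more compounds than this note shows. Statements on the series, on what has been measured and on what is new or still open speak of the compounds shown alone.

In an ADME assay on BaF3 cells (Mus musculus) for inhibition, read by CellTiter-Glo, with a stated time of 72 h (on this read-out lower numbers stand for stronger inhibition of growth and higher numbers for weaker inhibition of growth), compound 1 `CC(=O)N1CCN(c2ccc(Nc3ncc4c(n3)N(C)C(=O)N(c3cc(NC(=O)c5ccc(CN6CCC(N(C)C)C6)c(C(F)(F)F)c5)ccc3C)C4)cn2)CC1` gives 187 nM as its concentration for half-maximal growth inhibition. Compound 3 `Cc1cc(Nc2ncc3c(n2)N(C)C(=O)N(c2cc(NC(=O)c4cccc(C(F)(F)F)c4)ccc2C)C3)n(C)n1` gives 2060 nM in the same test, so compound 1 holds the lower of the two actual numbers, by a gap beyond the scatter. Compound 2 `Cc1ccc(Nc2ncc3c(n2)N(Cc2ccccc2)C(=O)N(c2cc(NC(=O)c4ccc(C)c(C(F)(F)F)c4)ccc2C)C3)cn1` reads > 5000 nM and this is a limit of the assay, not a number.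

Compound 4 `CCN1CCN(C(=O)c2ccc(Nc3ncc4c(n3)N(C)C(=O)N(c3cc(NC(=O)c5ccc(CN6CCC(N(C)C)C6)c(C(F)(F)F)c5)ccc3C)C4)cn2)CC1` has yet to be measured. It differs from compound 1 in one group only: (4-ethylpiperazin-1-yl)carbonyl in place of 4-acetylpiperazin-1-yl on an aromatic carbon and the change is (4-ethylpiperazin-1-yl)carbonyl in place of 4-acetylpiperazin-1-yl on an aromatic carbon. The site is on a six-membered aromatic ring with 1 nitrogen, next to the ring nitrogen and para to a large group.

Within the data shown here, no two measured compounds differ in just one place, so the data give no direct size for such a change. The expectation therefore rests on compound 1 and its 187 nM reading, with the rest of the structure unchanged. The expected 1.1-fold lower number from compound 1 to compound 4 (0.04 log units; within the scatter) in this assay is small, within the scatter and without a firm direction. Compound 4 is estimated at 170 nM with an expected range from 60 nM to 500 nM in this test.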

Compound 4, concentration for 50% growth inhibition: 704 nM
Beside the measured number, compound 4's estimate is 4.1-fold (0.62 log units) below it; measured number above the stated range.
By their numbers in this assay, from the lowest: compound 1; then compound 4; then compound 3. At a limit, above all of these: compound 2.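

In this assay, this pair gives the only direct measure of a single change on this scaffold: a 3.8-fold higher number from compound 1 to compound 4 (0.58 log units; beyond the scatter). The earlier compounds shown here could not show that the aromatic carbon next to the ring nitrogen and para to a large group responds to what it carries, and this step shows that it does, even though the two groups match in ring type, in double bonds outside aromatic rings, and in hydrogen-bond donors and acceptors. The measurements shown offer no explanation for the size or direction of this step.

The step combines two alterations, since a carbonyl now links the piperazine to the aromatic ring and an ethyl group replaces the acetyl group on the piperazine, so the compounds shown cannot say which of the two accounts for the shift. Also open, going by these compounds, is how the reading would respond to a morpholine ring, a simple primary amine or a carboxylic acid on this same carbon, with the rest of compound 1 kept unchanged.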